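Nitro to amino exchange in a sulfone series, cytotoxicity

The source may report more compounds than this note shows. Statements on the series, on what has been measured and on what is new or still open speak of the compounds shown alone.

Two pairs of sulfones are compared. Compound 1 `COc1ccc(CS(=O)(=O)/C=C/c2c(OC)cccc2OC)cc1[N+](=O)[O-]` and compound 2 `COc1ccc(CS(=O)(=O)CC(=O)Nc2c(C)cc(C)cc2C)cc1[N+](=O)[O-]` share the nitro-bearing aromatic ring but differ in the rest of the molecule; the difference between the two cores is not broken down here. Compound 3 `COc1ccc(CS(=O)(=O)CC(=O)Nc2c(C)cc(C)cc2C)cc1N` arises from compound 2 by amino in place of nitro on an aromatic carbon. Compound 4 `COc1ccc(CS(=O)(=O)/C=C/c2c(OC)cccc2OC)cc1N` arises from compound 1 by amino in place of nitro on an aromatic carbon, the same change in the same surroundings, described in identical words for both pairs.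

In an ADME assay on MRC5 cells (Homo sapiens) for cytotoxicity, read by MTT assay, with a stated time of 72 h (a lower number here means a stronger inhibitor of growth, a higher number a weaker inhibitor of growth), compound 2 gives 28000 nM. For compound 3 the reading is a limit of the assay, > 30000 nM. The measured step is an at least 1.0-fold higher number from compound 2 to compound 3 (0.02 log units; that floor lies within the scatter), and its floor rests on (the limit of > 30000 nM in this assay, at which 2 of the 3 values shown sit). For compound 1 the reading is also a limit, > 30000 nM.

Compound 4 is therefore expected to sit at the weak end of this assay, with an estimated value of 35000 nM, because an at least 1.0-fold higher number from compound 2 to compound 3 (0.02 log units; that floor lies within the scatter) shows the same exchange leaving the measured pair inside the scatter. The range expected for compound 4 runs from 18000 nM to 70000 nM. For compound 4 the expected step is a step that the limit leaves unreadable from compound 1 to compound 4. It is expected that the assay again reports only a limit for compound 4 rather than a number, so the measured result will decide whether anything beyond that can be said.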

Compound 4, concentration for 50% growth inhibition: 17100 nM
Beside the measured number, compound 4's estimate is 2.0-fold (0.31 log units) above it; the whole stated range lies above it.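

In this assay the exchange of nitro for amino gives an at least 1.7-fold lower number from compound 1 to compound 4 (0.24 log units; that floor lies within the scatter), and compound 4 is the only amino compound shown that reads as a number rather than a limit. Set beside the other core, the exchange gives no result that separates the two cores: the same change on two cores in this assay, an at least 1.0-fold higher number (0.02 log units; that floor lies within the scatter) from compound 2 to compound 3 and an at least 1.7-fold lower number (0.24 log units; that floor lies within the scatter) from compound 1 to compound 4; the limit leaves it open whether they differ Both floors lie within the scatter, so the pair shows neither that the change carries over from one core to another nor that it behaves differently on each, and the comparison rests largely on readings that are limits: the limit of > 30000 nM in this assay, at which 2 of the 4 values shown sit.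

On these data alone, what stays open is the true size of the exchange on either core, since compound 1 and compound 3 each supply only a limit, and with just two pairs no rule for the series can be drawn from them. Also open, as far as these compounds go, is how other groups on the same aromatic carbon, ortho to a methoxy group, would read in this assay, for example a hydroxyl group, a nitrile or a dimethylamino group, on either core.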